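The compounds below may be only part of what the source reports. "The series", "measured", "known", "first", "only" and "open" are said of these compounds alone.

Measured so far in a functional assay on MCF7 cells (Homo sapiens) for antiproliferative activity; a lower number here means a stronger inhibitor, a higher number a weaker inhibitor:
compound 1 `COc1cc(Cc2nc3c(N)ncnc3n2CC2CCCO2)cc(OC)c1OC` — 91200 nM
compound 2 `COc1cc(Cc2nc3c(N)ncnc3n2CCCC(C)C)cc(OC)c1OC` — 69200 nM
compound 3 `COc1cc(Cc2nc3c(N)ncnc3n2CC2CCC2)cc(OC)c1OC` — 45700 nM

Compound 3 carries the lowest of the three numbers, yet neither a 2.0-fold lower number from compound 1 to compound 3 (0.30 log units; within the scatter) nor a 1.5-fold lower number from compound 2 to compound 3 (0.18 log units; within the scatter) reaches beyond the scatter, and a 1.3-fold lower number from compound 1 to compound 2 (0.12 log units; within the scatter) does not either. The three groups on the saturated chain carbon bound to an aromatic nitrogen therefore give numbers that cannot be told apart. Compound 4 `COc1cc(Cc2nc3c(N)ncnc3n2CC2CC2)cc(OC)c1OC` varies the same place once more: cyclopropyl in place of cyclobutyl on a saturated chain carbon bound to an aromatic nitrogen. Every change at this place seen so far moved the number less than the scatter, so no step beyond the scatter is expected in this assay. Compound 4 is expected to give 45000 nM, within 20000 nM to 100000 nM. The expected step is a 1.0-fold lower number from compound 3 to compound 4 (0.01 log units; within the scatter).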

Compound 4, half-maximal inhibitory concentration: 75900 nM
Compound 4: the middle estimate sits 1.7-fold (0.23 log units) below what was measured; low and high end bracket the measured number.
By their numbers in this assay, from the lowest: compounds 3, 2, 4 and 1 (each within the scatter of the next).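

In this assay the cyclopropyl group on a saturated chain carbon bound to an aromatic nitrogen cannot be told apart from any of the three earlier groups: a 1.7-fold higher number from compound 3 to compound 4 (0.22 log units; within the scatter), a 1.1-fold higher number from compound 2 to compound 4 (0.04 log units; within the scatter) and a 1.2-fold lower number from compound 1 to compound 4 (0.08 log units; within the scatter). Going from cyclobutyl to cyclopropyl therefore adds no readable difference, and all four groups at this place remain within the scatter of one another. No supporting data bear on this result.

Going by these compounds, whether an amine or a carboxylic acid at this place would separate from these four groups stays open. So does whether any change elsewhere on the shared core would move the number beyond the scatter.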